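Replacing the Methoxyazetidine on the Carbonyl of Compound 1

This account rests on a few compounds, and the source may have more. Where it says the series, first, only, none or still open, it means among the compounds named here.

In an ADME assay (Rattus norvegicus, strain Wistar Han) for metabolic stability (a lower number here means that the compound disappears faster, a higher number that the compound lasts longer), compound 1 (`CCn1c(-c2cnc(C)nc2)nc2c(N[C@H]3CCN(C(=O)N4CC(OC)C4)C3)ncnc21`) gives 4 h, which places it at the upper end of the three numbers available. Compound 2 (`CCn1c(-c2ccc(C(F)(F)F)nc2)nc2c(O[C@H]3CCN(C(=O)C4CCOC4)C3)ncnc21`) gives 2.3 h, which lies within the usual scatter of the number for compound 1. Compound 3 (`CCC(=O)N1CC[C@H](Oc2ncnc3c2nc(-c2cnc(C)nc2)n3CC)C1`) gives 1.2 h, which lies lower than the number for compound 1 and beyond the scatter.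

Compound 4 (`CCn1c(-c2cnc(C)nc2)nc2c(N[C@H]3CCN(C(=O)C4CC4)C3)ncnc21`) has not yet been measured. It differs from compound 1 in one place, on a carbonyl carbon whose other neighbours are an amide-type nitrogen in a ring, where cyclopropyl stands in place of 3-methoxyazetidin-1-yl (cyclopropyl in place of 3-methoxyazetidin-1-yl on a carbonyl carbon).

Among the measured compounds shown here, no measured pair isolates this change, and both compound 2 and compound 3 also differ from compound 1 elsewhere, so the evidence is thin. Neither of them carries 3-methoxyazetidin-1-yl, and the expectation leans on compound 3 at 1.2 h and compound 2 at 2.3 h. A modest move toward a lower number is therefore expected in this assay, probably without clearing the scatter. The expected change is a 1.6-fold lower number from compound 1 to compound 4 (0.20 log units; within the scatter). For compound 4 the estimated half-life is 2.5 h, with an expected range from 1.2 h to 5 h.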

Compound 4, half-life: 2.7 h
Estimate against measurement, compound 4: 1.1-fold (0.03 log units) below, within the range that was stated.
By their numbers in this assay, from the lowest: compounds 3, 2, 4 and 1 (each within the scatter of the next, the first and the last beyond it).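

In this assay, among the compounds shown here, this pair gives the first reading of a change at this position alone, since compound 2 and compound 3 also differ from compound 1 elsewhere: a 1.5-fold lower number from compound 1 to compound 4 (0.17 log units; within the scatter). With the step inside the scatter, the half-life does not separate the two compounds, even though (3-methoxyazetidin-1-yl)carbonyl gives way to cyclopropylcarbonyl, which takes the group on the carbonyl carbon from 6 heavy atoms to 3, removes its 1 hydrogen-bond acceptor and replaces a four-membered ring holding a hetero atom with a three-membered ring of carbon only. Nothing among the data shown explains this outcome at the level of the structures.

What the compounds shown leave open is whether any group on this carbonyl carbon can give a step beyond the scatter, for instance a morpholine, a dimethylamine or a longer carbon chain such as butyl. As far as these compounds go, it also remains open whether cyclopropyl in place of 3-methoxyazetidin-1-yl would read the same in a compound that differs from compound 1 elsewhere, as this single pair speaks only for the setting of compound 1.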